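Chain extension of the acrylamide in two parallel cases

The compounds below may be only part of what the source reports. "The series", "measured", "known", "first", "only" and "open" are said of these compounds alone.

Compound 1, `C=CC(=O)Nc1cc(Nc2nc(C)cc(-c3cn(C)c4ccccc34)n2)c(OC)cc1N(C)CCN(C)C`, gives 12600 nM in a functional assay on HepG2 cells (Homo sapiens) for antiproliferative activity, read by MTT assay, with a stated time of 72 h; on this read-out lower numbers stand for stronger inhibition and higher numbers for weaker inhibition.
Compound 2, `CC/C=C\C(=O)Nc1cc(Nc2nc(C)cc(-c3cn(C)c4ccccc34)n2)c(OC)cc1N(C)CCN(C)C`, gives 2050 nM in this assay.
Compound 3, `C=CC(=O)Nc1cc(Nc2ncc(C#N)c(-c3cn(C)c4ccc(F)cc34)n2)c(OC)cc1N(C)CCN(C)C`, gives 17500 nM in this assay.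

Compound 1 and compound 2 share one core and differ in a single place: but-1-en-1-yl in place of vinyl on a carbonyl carbon. This change produced a 6.1-fold lower number from compound 1 to compound 2 (0.79 log units; beyond the scatter). Compound 3 carries a different core; the difference between the two cores is not broken down here. Among the three measured numbers compound 3 stands highest, with compound 1 within the scatter of it and compound 2 beyond it.

Compound 4, `CC/C=C\C(=O)Nc1cc(Nc2ncc(C#N)c(-c3cn(C)c4ccc(F)cc34)n2)c(OC)cc1N(C)CCN(C)C`, has not yet been measured. It stands to compound 3 exactly as compound 2 stands to compound 1, and the change is the same: but-1-en-1-yl in place of vinyl on a carbonyl carbon. Because the same change gave a 6.1-fold lower number from compound 1 to compound 2 (0.79 log units; beyond the scatter) on the other core, a step of similar size is expected on this core, and compound 4 is expected to show a 5.0-fold lower number from compound 3 to compound 4 (0.70 log units; beyond the scatter). Within the data shown here, only one earlier instance of the change supports this, so the expectation is held loosely. Compound 4 is estimated at 3500 nM, with a likely range from 1500 nM to 9000 nM.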

Compound 4, half-maximal inhibitory concentration: 5880 nM
Compound 4: middle estimate off by 1.7-fold (0.23 log units), on the low side, and the stated range covers the measured number.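

In this assay, but-1-en-1-yl in place of vinyl on a carbonyl carbon again lowered the number, giving a 3.0-fold lower number from compound 3 to compound 4 (0.47 log units; beyond the scatter). Set beside the earlier case, the step runs in the same direction, and the gap in size between the two steps does not exceed what scatter alone would give: the same change on two cores in this assay, a 6.1-fold lower number (0.79 log units; beyond the scatter) from compound 1 to compound 2 and a 3.0-fold lower number (0.47 log units; beyond the scatter) from compound 3 to compound 4, 2.1-fold (0.31 log units) apart, within the scatter of two such steps. Among these compounds, this shows that the change carried over from one core to the other, in direction and in size as far as this read-out can tell, but with only two cores it does not establish a rule for other cores, and it says nothing about why the number falls.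

The compounds shown leave open whether a longer chain than but-1-en-1-yl on the carbonyl carbon, or one ending in an amine or a carboxylic acid, would extend the step or reverse it. They also leave open whether the step would persist on a core carrying only one of the differences between the two cores shown.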